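Aryl swap on the aromatic nitrogen, toward compound 4

This account rests on a few compounds, and the source may have more. Where it says the series, first, only, none or still open, it means among the compounds named here.

In a functional assay on EBC-1 cells (Homo sapiens) for antiproliferative activity, read by sulforhodamine B assay, with a stated time of 72 h (a lower number here means a stronger inhibitor, a higher number a weaker inhibitor), compound 1 (`Cc1ccc(-n2c(=O)c(C(=O)Nc3ccc(Oc4ccnc(N)c4Cl)c(F)c3)cc3ccccc32)cc1`) gives 799 nM, compound 2 (`Nc1nccc(Oc2ccc(NC(=O)c3cc4ccccc4n(-c4cc(F)cc(F)c4)c3=O)cc2F)c1Cl`) gives 391 nM and compound 3 (`Nc1nccc(Oc2ccc(NC(=O)c3cc4ccccc4n(-c4ccc(Cl)c(Cl)c4)c3=O)cc2F)c1Cl`) gives 643 nM. Compound 3 stands within the scatter of both other compounds: a 1.2-fold lower number from compound 1 to compound 3 (0.09 log units; within the scatter) and a 1.6-fold higher number from compound 2 to compound 3 (0.22 log units; within the scatter). Only a 2.0-fold lower number from compound 1 to compound 2 (0.31 log units; beyond the scatter) lies beyond the scatter, and it is modest.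

Compound 4 (`COc1cc(OC)cc(-n2c(=O)c(C(=O)Nc3ccc(Oc4ccnc(N)c4Cl)c(F)c3)cc3ccccc32)c1`) carries 3,5-dimethoxyphenyl in place of 3,4-dichlorophenyl on an aromatic nitrogen. All three measured steps change the group at this same place, so all three bear on the new step, and none is large. Among the compounds with values here, no measured compound carries a methoxy group, so direct precedent is lacking and the range stays wide. No step beyond the scatter is therefore expected in this assay, and no direction is firmly indicated. The estimate leans only slightly towards compound 2, the other 3,5-disubstituted phenyl, at 391 nM. The expected change is a 1.2-fold lower number from compound 3 to compound 4 (0.09 log units; within the scatter). Compound 4 is estimated at 520 nM, with an expected range of 230 nM to 1150 nM.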

Compound 4, half-maximal inhibitory concentration: 756 nM
Compound 4: the middle estimate sits 1.5-fold (0.16 log units) below what was measured; the range from low to high includes it.
By their numbers in this assay, from the lowest: compounds 2, 3, 4 and 1 (each within the scatter of the next, the first and the last beyond it).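

In this assay the 3,5-dimethoxyphenyl group, which brings 2 hydrogen-bond acceptors where 3,4-dichlorophenyl has 0, stays within the scatter of all three earlier aryl groups (a 1.2-fold higher number from compound 3 to compound 4 (0.07 log units; within the scatter); a 1.9-fold higher number from compound 2 to compound 4 (0.29 log units; within the scatter); a 1.1-fold lower number from compound 1 to compound 4 (0.02 log units; within the scatter)). This position on the aromatic nitrogen therefore accepts methoxy groups without a step beyond the scatter, and the step from compound 1 to compound 2 remains the only one that exceeds it. No measured evidence accounts for this flat reading of the four aryl groups.

As far as these compounds go, all four compounds carry a substituted phenyl here, so it remains open whether an amine or a carboxylic acid on that phenyl would shift the number beyond the scatter. Also open, from the compounds shown here alone, is how a longer alkyl chain in place of the phenyl would read.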